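Chain extension from compound 2 to compound 3

The compounds below may be only part of what the source reports. "The series", "measured", "known", "first", "only" and "open" are said of these compounds alone.

In a functional assay on A549 cells (Homo sapiens) for antiproliferative activity, read by MTT assay, with a stated time of 48 h (on this read-out higher numbers stand for weaker inhibition and lower numbers for stronger inhibition), compound 1 `CCCC(C)Oc1ccc(C(=O)/C=C/c2c(/C=C/c3ccc(OC)cc3)cc(OC)cc2OC)cc1` gives 9.4 ug/mL and compound 2 `CCCCOc1ccc(C(=O)/C=C/c2c(/C=C/c3ccc(OC)cc3)cc(OC)cc2OC)cc1` gives 8.7 ug/mL. For the measured compounds named here, these are the only two numbers so far and they lie within the scatter of each other, so compound 2 is not separated from compound 1.

Compound 3 `CCCCCCOc1ccc(C(=O)/C=C/c2c(/C=C/c3ccc(OC)cc3)cc(OC)cc2OC)cc1` keeps the shared core and differs from compound 2 only in the chain: ethyl in place of hydrogen on a saturated chain carbon, four bonds along the chain from an oxygen on an aromatic ring. The change sits on a saturated chain carbon, four bonds along the chain from an oxygen on an aromatic ring.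

Going by the values given here, one measured step touches this chain: a 1.1-fold lower number from compound 1 to compound 2 (0.03 log units; within the scatter), with hydrogen in place of methyl on a saturated chain carbon bound to an oxygen on an aromatic ring. Among the compounds with values here, that step concerns a different carbon and a different group, so it is weak guidance, and no measured step covers ethyl at the new place. No step beyond the scatter is therefore expected in this assay, and neither direction is favoured. The expected step is a 1.0-fold lower number from compound 2 to compound 3 (0.01 log units; within the scatter). The estimate for compound 3 is 8.5 ug/mL, with an expected range of 4.5 ug/mL to 16 ug/mL.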

Compound 3, half-maximal inhibitory concentration: 8.4 ug/mL
The estimate for compound 3 lay 1.0-fold (0.01 log units) above the measured number; the measured number falls inside the stated range.
By their numbers in this assay, from the lowest: compounds 3, 2 and 1 (each within the scatter of the next).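

In this assay, ethyl in place of hydrogen on a saturated chain carbon, four bonds along the chain from an oxygen on an aromatic ring, gives a 1.0-fold lower number from compound 2 to compound 3 (0.02 log units; within the scatter), so this position now has a measured change of its own, and that change does not separate the butyl and hexyl ethers. The wider comparison, hexyl in place of 1-methylbutyl on an oxygen on an aromatic ring, gives a 1.1-fold lower number from compound 1 to compound 3 (0.05 log units; within the scatter), which places this straight-chain ether with the branched one as well. Compound 1, compound 2 and compound 3 are therefore all within the scatter of one another, and the earlier pair, which addressed only the methyl on the chain carbon bound to the oxygen, could not show this for the far end of the chain; no supporting data bear on the result.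

The compounds shown leave open whether a longer chain such as decyl on the same oxygen would stand apart from these three. They also leave open whether a hexyl chain ending in an amine or a carboxylic acid would do so.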